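The compounds below may be only part of what the source reports. "The series", "measured", "known", "first", "only" and "open" are said of these compounds alone.

Of the compounds shown here, three with one shared core have been measured in a functional assay on UO-31 cells (Homo sapiens) for inhibition, read by sulforhodamine B assay, with a stated time of 48 h (a lower number here means that less compound is tolerated, a higher number that more compound is tolerated), and every one of them returned only a limit rather than a number. Compound 1 `O=C(Nc1cccc(-n2cc(-c3ccncc3)c(-c3ccc(Cl)c(O)c3)n2)c1)Nc1ccc(Cl)c(Cl)c1` gives > 32500 nM in this assay, which is a limit. Compound 2 `COc1cc(-c2nn(-c3cccc(NC(=O)c4cccc(C(F)(F)F)c4)c3)cc2-c2ccncc2)ccc1Cl` gives > 50000 nM, also a limit. Compound 3 `COc1cc(-c2nn(-c3cccc(NC(=O)Nc4cccc(C(F)(F)F)c4)c3)cc2-c2ccncc2)ccc1Cl` gives > 50000 nM, again a limit. The one change between two measured compounds, a step that the two limits leave unreadable from compound 2 to compound 3, therefore cannot be read for size, as the limit of > 32500 nM in this assay, at which 1 of the 3 values shown sits, and the limit of > 50000 nM in this assay, at which 2 of the 3 values shown sit, make plain: all three values sit at the limits and no compound has so far shown a readable number.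

For the measured compounds named here, compound 3 thus stands where every measured neighbour stands, at a limit, with no measured step in this assay that could be sized.

Compound 4 `COc1cc(-c2nn(-c3cccc(NC(=O)c4ccccc4)c3)cc2-c2ccncc2)ccc1Cl` differs from compound 3 in one place: phenyl in place of (3-(trifluoromethyl)phenyl)amino on a carbonyl carbon. Going by the values given here, the only step measured between compounds, from compound 2 to compound 3, touches the same carbonyl carbon and is itself unreadable, so it gives no direction to expect. For compound 4 the expectation is that this assay again reports a limit, with a step of a number no higher from compound 3 to compound 4 (the limit leaves the size open) that is not expected to reach beyond the scatter. The estimate for compound 4 is 50000 nM, with a range from 20000 nM to 100000 nM.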

Compound 4, concentration lethal to 50% of the cells: > 100000 nM
Compound 4 was reported as a limit (the forecaster's own chance of this, stated with the estimate: 85%); middle value at least 2.0-fold (0.30 log units) from the limit.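

In this assay compound 4 gives > 100000 nM, which is a limit. Compound 2 and compound 3 also stand at limits, so neither step to compound 4 can be read for size. The compounds shown leave open whether any compound with this shared core would give a readable number in this assay.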